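Demethylation of the 2-methoxyphenoxy Group: From Compound 3 to 4

A few compounds are considered here, and "the series" means these few. Any claim that something is new, unique, unknown or untested is made for them only; others in the source may bear on it.

Measured compounds:
compound 1 `Cc1ccc(C#N)c(OC(C)(C)C2OCC(C/C=C\CCC(=O)O)C(c3cccnc3)O2)c1`, 50 nM
compound 2 `COc1ccc(OC(C)(C)C2OCC(C/C=C\CCC(=O)O)C(c3cccnc3)O2)cc1`, 41 nM
compound 3 `COc1ccccc1OC(C)(C)C1OCC(C/C=C\CCC(=O)O)C(c2cccnc2)O1`, 60 nM

In an assay for inhibition of Thromboxane-A synthase (Homo sapiens), using microsomes (a lower number here means a stronger inhibitor, a higher number a weaker inhibitor), compound 3 gives 60 nM, the highest of the three numbers, yet all three sit within the scatter of one another: a 1.2-fold higher number from compound 1 to compound 3 (0.08 log units; within the scatter) and a 1.5-fold higher number from compound 2 to compound 3 (0.17 log units; within the scatter), while a 1.2-fold lower number from compound 1 to compound 2 (0.09 log units; within the scatter). The aryl group on the oxygen on a saturated carbon has thus so far made no difference that rises above the scatter.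

Compound 4 `CC(C)(Oc1ccccc1O)C1OCC(C/C=C\CCC(=O)O)C(c2cccnc2)O1` carries hydrogen in place of methyl on an oxygen on an aromatic ring, that is, the 2-methoxyphenyl of compound 3 becomes 2-hydroxyphenyl. Within the data shown here, no measured pair shows this particular change; the only guidance is that replacing the whole aryl group in the three measured steps left this assay unchanged within the scatter. The expectation is therefore a step in this assay of about no change at the digits printed from compound 3 to compound 4 (within the scatter), no change beyond the scatter in either direction. Compound 4 is estimated at 60 nM, in the range 25 nM to 150 nM.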

Compound 4, half-maximal inhibitory concentration: 32 nM
For compound 4 the middle estimate is 1.9-fold (0.27 log units) above the measured one; low and high end bracket the measured number.
By their numbers in this assay, from the lowest: compounds 4, 2, 1 and 3 (each within the scatter of the next).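

In this assay, the methyl on the oxygen on an aromatic ring can give way to hydrogen with a step of a 1.9-fold lower number from compound 3 to compound 4 (0.27 log units; within the scatter). The earlier compounds shown here exchanged whole aryl groups, whereas this step alters only the methoxy, and the resulting 2-hydroxyphenyl stays level with the other aryl groups, with a 1.3-fold lower number from compound 2 to compound 4 (0.11 log units; within the scatter) and a 1.6-fold lower number from compound 1 to compound 4 (0.19 log units; within the scatter). Nothing available bears on what lies behind this result.

It remains open whether an amine or a longer chain such as ethoxy in place of the hydroxy would carry the number beyond the scatter, which no step among these four compounds does. Also open, on these data alone, is whether the same change of methyl to hydrogen on the 4-methoxyphenyl of compound 2 would give a similar step.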